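The source may hold more compounds than are shown below. What is called first, only, known or untested is meant among the compounds shown, and "the series" means these compounds.

The measured compounds so far:

Compound 1, `CCc1c(C(C)c2c(F)cccc2F)nc(SC(C)C)[nH]c1=O`, gives > 3000 nM.
Compound 2, `CCCSc1nc(C(C)c2c(F)cccc2F)c(CC)c(=O)[nH]1`, gives > 3000 nM.
Compound 3, `CCC(c1nc(SC(C)C)[nH]c(=O)c1C)c1c(F)cccc1F`, gives > 30000 nM.

All three were tested in an ADME assay on MT4 cells (Homo sapiens) for activation, read by MTT assay; a lower number here means that less compound is tolerated, a higher number that more compound is tolerated. For compound 1 the result of > 3000 nM is a limit of the assay, not a measured number. For compound 2 the result of > 3000 nM is likewise a limit. The two compounds differ in one place, (propyl in place of isopropyl on a sulfur), and the step between them is a step that the two limits leave unreadable from compound 1 to compound 2; both sit at the limit of > 3000 nM in this assay, at which 2 of the 3 values shown sit, so the size of that step cannot be read. For compound 3 the result of > 30000 nM is again a limit, this time (the limit of > 30000 nM in this assay, at which 1 of the 3 values shown sits). How the core of compound 3 differs from that of compound 1 is not broken down here.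

Compound 4, `CCCSc1nc(C(CC)c2c(F)cccc2F)c(C)c(=O)[nH]1`, has not yet been measured. Going by the values given here, it differs from compound 3 by propyl in place of isopropyl on a sulfur, the same change as the one from compound 1 to compound 2, made at a place described in the same words. Since compound 3 stands at > 30000 nM and the same change between compound 1 and compound 2 left both at the limit of > 3000 nM in this assay, at which 2 of the 3 values shown sit, the expected step of a number no higher from compound 3 to compound 4 (the limit leaves the size open) is small, and it is most likely that compound 4 will again be reported only as a limit. For compound 4 the estimated value is 30000 nM, with the expected range running from 10000 nM to 100000 nM.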

Compound 4, half-maximal cytotoxic concentration: > 3000 nM
Compound 4: only a limit was reported (the forecaster's own chance of this, stated with the estimate: 80%); the middle value is on the limit's open side.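

In this assay, compound 3 and compound 4 are each reported only as a limit of the assay, not as a number, and the step between them, propyl in place of isopropyl on a sulfur, cannot be read. The compounds shown leave open how much of each compound is actually tolerated, and whether this change on the sulfur shifts that amount at all.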